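The compounds below may be only part of what the source reports. "The series", "measured", "known", "first", "only" and "open" are said of these compounds alone.

The series shares one core; compound 1 is `N#Cc1ccc(Nc2nc(Oc3ccnc4ccccc34)nc(N3CCN(c4ccccc4Cl)CC3)n2)cc1C(F)(F)F`, compound 2 is `N#Cc1ccc(Nc2nc(Oc3ccnc4ccccc34)nc(N3CCN(c4ccc(F)cc4)CC3)n2)cc1C(F)(F)F`, compound 3 is `CN1CCN(c2nc(Nc3ccc(C#N)c(C(F)(F)F)c3)nc(Oc3ccnc4ccccc34)n2)CC1` and the unmeasured compound 4 is `N#Cc1ccc(Nc2nc(Oc3ccnc4ccccc34)nc(N3CCN(c4cccc(C(F)(F)F)c4)CC3)n2)cc1C(F)(F)F`. In a functional assay on DU-145 cells (Homo sapiens) for cytotoxicity, read by sulforhodamine B assay, with a stated time of 48 h (on this read-out higher numbers stand for weaker inhibition of growth and lower numbers for stronger inhibition of growth), compound 1 gives only a limit, > 100000 nM. In this assay compound 2 likewise gives a limit, > 100000 nM. In this assay compound 3 also gives a limit, > 100000 nM. Compound 3 therefore cannot be placed against the other two: all three values sit at the same limit, (the limit of > 100000 nM in this assay, at which 3 of the 3 values shown sit), and the steps a step that the two limits leave unreadable from compound 1 to compound 2, a step that the two limits leave unreadable from compound 1 to compound 3 and a step that the two limits leave unreadable from compound 2 to compound 3 are unreadable. The change to compound 4 is 3-(trifluoromethyl)phenyl in place of methyl on an amine nitrogen in a ring. The steps between compound 3 and compounds 1 and 2 bear most directly on it, and neither could be read. With no readable step in the set, and every variant on this ring nitrogen at the limit, compound 4 is expected to sit at the limit as well, the expected step being a step that the limit leaves unreadable from compound 3 to compound 4. Compound 4 is estimated at 150000 nM, within 50000 nM to 500000 nM, most likely reported only as a limit.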

Compound 4, concentration for total growth inhibition: 74100 nM
Compound 4: middle estimate off by 2.0-fold (0.31 log units), on the high side; low and high end bracket the measured number.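

In this assay compound 4 gives 74100 nM, a number and not a limit, so this ring nitrogen now has one variant that can be read. The comparison yields only floors, an at least 1.3-fold lower number from compound 3 to compound 4 (0.13 log units; that floor lies within the scatter) and an at least 1.3-fold lower number from compound 2 to compound 4 (0.13 log units; that floor lies within the scatter) and an at least 1.3-fold lower number from compound 1 to compound 4 (0.13 log units; that floor lies within the scatter), so 3-(trifluoromethyl)phenyl is not shown to differ from methyl, 4-fluorophenyl or 2-chlorophenyl beyond the scatter. The steps among compound 1, compound 2 and compound 3 still cannot be read, and those compounds stay together at one limit: the limit of > 100000 nM in this assay, at which 3 of the 4 values shown sit.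

Open, from the compounds shown here alone, is whether the true gap from those three compounds to compound 4 exceeds the scatter at all. Also open, going by these compounds, is whether a longer chain on this ring nitrogen, or an amine or a carboxylic acid on its phenyl ring, would bring the number clearly lower.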